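Branched versus straight dialkylamino groups on a shared core

The compounds below may be only part of what the source reports. "The series", "measured", "known", "first", "only" and "open" are said of these compounds alone.

Compound 1 `CN(C)c1nc2c(ncn2-c2ccccc2)c(=O)n1-c1ccccc1` in a functional assay on HepG2 cells (Homo sapiens) for cytotoxicity, read by MTT assay, with a stated time of 72 h (on this read-out lower numbers stand for stronger inhibition and higher numbers for weaker inhibition), gives > 100000 nM, a limit of the assay rather than a number.
Compound 2 `CCCCN(CCCC)c1nc2c(ncn2-c2ccccc2)c(=O)n1-c1ccccc1` in this assay gives 20400 nM.

Among the compounds with values here, compound 2 thus carries the only numerical value; the other result is the limit of > 100000 nM in this assay, at which 1 of the 2 values shown sits. Within the data shown here, the one measured step, an at least 4.9-fold lower number from compound 1 to compound 2 (0.69 log units; beyond the scatter), shows that enlarging the dialkylamino group lowers the number. Compound 3 `CC(C)N(c1nc2c(ncn2-c2ccccc2)c(=O)n1-c1ccccc1)C(C)C` makes a smaller change, (diisopropylamino in place of dibutylamino on an aromatic carbon), a group in size between those of compound 1 and compound 2. Compound 3 is therefore expected to land between them, with an estimated 2.5-fold higher number from compound 2 to compound 3 (0.39 log units; beyond the scatter), giving a value near 50000 nM (range 15000 nM to 150000 nM), though a limit is possible.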

Compound 3, half-maximal inhibitory concentration: > 100000 nM
Compound 3 gave a limit, no number (the forecaster's own chance of this, stated with the estimate: 35%); middle value at least 2.0-fold (0.30 log units) away from the limit.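

Diisopropylamino in place of dibutylamino on this aromatic carbon gives an at least 4.9-fold higher number from compound 2 to compound 3 (0.69 log units; beyond the scatter), so enlarging the dialkylamino group does not by itself lower the number. Compound 1 and compound 3 both rest on a limit, not a number: the limit of > 100000 nM in this assay, at which 2 of the 3 values shown sit. The step from compound 1 to compound 3 cannot be read.

Going by these compounds, whether the lower number of compound 2 follows its straight chains or its carbon count stays open, and diisobutylamino or dipropylamino would help separate the two. On these data alone, whether a longer chain, such as dihexylamino, would lower the number further is also open.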